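Three inactive esters and an untested amide

The source may hold more compounds than are shown below. What is called first, only, known or untested is meant among the compounds shown, and "the series" means these compounds.

Compound 1 `CCOC(=O)c1ccc(-c2nn(Cc3ccccc3F)c3ccccc23)cc1` gives > 10000 nM in this test
Compound 2 `COC(=O)c1ccc(-c2nn(Cc3ccccc3)c3ccccc23)cc1` gives > 10000 nM in this test
Compound 3 `CC(C)OC(=O)c1ccc(-c2nn(Cc3ccccc3)c3ccccc23)cc1` gives > 10000 nM in this test

In a functional assay on cells (Platelet, Homo sapiens) for inhibition (a higher number here means a weaker inhibitor, a lower number a stronger inhibitor), compound 3 stands at > 10000 nM as a limit, not a number. Compounds 1 and 2 give limits as well, and the shared ceiling is summed up here (the limit of > 10000 nM in this assay, at which 3 of the 3 values shown sit). Among the measured compounds shown here, the one measured step (a step that the two limits leave unreadable from compound 2 to compound 3) changes only the group on the oxygen and has no readable size.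

Compound 4 `CCNC(=O)c1ccc(-c2nn(Cc3ccccc3)c3ccccc23)cc1` carries ethylamino in place of isopropoxy on a carbonyl carbon, so isopropoxycarbonyl gives way to ethylcarbamoyl. For the measured compounds named here, no measured step covers this kind of change, so the data give no firm direction. Compound 3 at > 10000 nM is the only anchor, so compound 4 is expected to stay near that limit. The expected step (a number no higher from compound 3 to compound 4 (the limit leaves the size open)) therefore rests on no measured size. For compound 4 the estimated value is 10000 nM with an expected range from 2500 nM to 30000 nM in this assay when measured.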

Compound 4, half-maximal inhibitory concentration: > 10000 nM
Compound 4 ended at the assay's limit (the forecaster's own chance of this, stated with the estimate: 70%); the middle value lies on the limit itself.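

Compound 4 gives a limit and not a number, as do compound 2 and compound 3, so the steps to compound 4 cannot be read: the limit of > 10000 nM in this assay, at which 4 of the 4 values shown sit. The compounds shown leave open which change to the shared core, if any, would give a measurable value.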